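This account rests on a few compounds, and the source may have more. Where it says the series, first, only, none or still open, it means among the compounds named here.

Measured so far:
compound 1, `O=C1CC(=C(c2ccccc2)c2ccccc2)C(=O)N1CCN1CCN(c2cccc(C(F)(F)F)c2)CC1`, an assay on membranes from Cerebral cortex for binding affinity to Adrenergic receptor alpha-1 (Rattus norvegicus), read by radioligand binding; a lower number here means a stronger inhibitor, a higher number a weaker inhibitor: > 1000 nM, a limit of the assay rather than a number.
compound 2, `O=C1CC(=C(c2ccccc2)c2ccccc2)C(=O)N1CCCN1CCN(c2ccccc2)CC1`: 5.7 nM.
compound 3, `COc1ccccc1N1CCN(CCCN2C(=O)CC(=C(c3ccccc3)c3ccccc3)C2=O)CC1`: 8.1 nM.

Compound 3 thus carries the higher of the two numbers, with compound 2 nearest; the step of a 1.4-fold higher number from compound 2 to compound 3 (0.15 log units; within the scatter) is within the scatter, so the two are read as alike. Compound 1 stands apart, as its value is only a limit (the limit of > 1000 nM in this assay, at which 1 of the 3 values shown sits).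

Compound 4, `O=C1CC(=C(c2ccccc2)c2ccccc2)C(=O)N1CCCN1CCN(c2cccc(C(F)(F)F)c2)CC1`, is not yet measured. It differs from compound 3 by 3-(trifluoromethyl)phenyl in place of 2-methoxyphenyl on an amine nitrogen in a ring. Among the compounds with values here, the only measured step touching the same position, a 1.4-fold higher number from compound 2 to compound 3 (0.15 log units; within the scatter), is within the scatter. Within the data shown here, compound 1 carries the same 3-(trifluoromethyl)phenyl group on a different core and gives only a limit, but no step connects it to compound 4, so its value shows only that. The expected step of a 4.9-fold higher number from compound 3 to compound 4 (0.69 log units; beyond the scatter) is therefore a modest move towards a higher number, with wide uncertainty. Compound 4 is estimated at 40 nM, in the range 8 nM to 250 nM.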

Compound 4, inhibition constant: 62.7 nM
Compound 4: middle estimate off by 1.6-fold (0.20 log units), on the low side, and the stated range covers the measured number.
By their numbers in this assay, from the lowest: compounds 2 and 3 (each within the scatter of the next); then compound 4. At a limit, above all of these: compound 1.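

The group on the amine nitrogen in a ring is not a silent position in this assay: methoxy in place of hydrogen gave only a 1.4-fold higher number from compound 2 to compound 3 (0.15 log units; within the scatter), whereas a real shift appears with a 7.7-fold higher number from compound 3 to compound 4 (0.89 log units; beyond the scatter) and with an 11-fold higher number from compound 2 to compound 4 (1.04 log units; beyond the scatter). Trifluoromethyl on the phenyl ring therefore separates compound 4 from both compound 2 and compound 3, while those two remain alike. Nothing measured here accounts for this shift.

From the compounds shown here alone, whether the higher number belongs to the trifluoromethyl group itself or to where it sits on the phenyl ring remains open. A chloro or fluoro group on that ring, or a pyridine in place of the phenyl ring, would give the next comparisons at this nitrogen.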